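Working notes: from compound 2 to compound 3

The source may hold more compounds than are shown below. What is called first, only, known or untested is meant among the compounds shown, and "the series" means these compounds.

Measured in a functional assay on A549 cells (Homo sapiens), read by MTT assay, with a stated time of 72 h; a higher number here means a weaker inhibitor, a lower number a stronger inhibitor:
- compound 1 `Nc1nc(N)c2c(-c3cc4ccccc4o3)cn([C@@H]3O[C@H](CO)[C@@H](O)[C@H]3O)c2n1`: > 20000 nM (a limit)
- compound 2 `COc1nc(N)nc2c1c(-c1ccccc1)cn2[C@@H]1O[C@H](CO)[C@@H](O)[C@H]1O`: > 20000 nM (a limit)

Compound 2 gives no number in this assay, only a limit, and sits at the limit of > 20000 nM in this assay, at which 2 of the 2 values shown sit. Compound 3 `COc1nc(N)nc2c1c(-c1cc3ccccc3o1)cn2[C@@H]1O[C@H](CO)[C@@H](O)[C@H]1O` carries 1-benzofuran-2-yl in place of phenyl on an aromatic carbon of the five-membered aromatic ring with 1 nitrogen: 1-benzofuran-2-yl in place of phenyl on an aromatic carbon.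

Among the compounds with values here, no measured step is available to size this change. Compound 1 also bears 1-benzofuran-2-yl, and its > 20000 nM is a limit. On that basis, no clear gain in this assay is expected. The estimated step of a number no higher from compound 2 to compound 3 (the limit leaves the size open) is expected to stay within the scatter, with neither direction favoured. The expected value for compound 3 is 20000 nM, within an estimated range of 7000 nM to 40000 nM.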

Compound 3, half-maximal inhibitory concentration: > 20000 nM
Compound 3 gave a limit, no number; the forecaster's own chance of this, stated with the estimate: 80%; the middle value lies on the limit itself.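

Compound 3 also gives a limit in this assay, and the steps to it from compound 1 and from compound 2 cannot be read: the limit of > 20000 nM in this assay, at which 3 of the 3 values shown sit.

The compounds shown leave open whether 1-benzofuran-2-yl in place of phenyl, or methoxy in place of amino, shifts the read-out in this assay at all.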